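Swapping Chloro for Phenylsulfanyl on a Kinase-Binding Series

The source may hold more compounds than are shown below. What is called first, only, known or untested is meant among the compounds shown, and "the series" means these compounds.

In an assay on isolated protein for inhibition of Rho-associated protein kinase 1 (Homo sapiens), tested at 30 uM (on this read-out higher numbers stand for more inhibition at the one concentration tested (going by the name of the read-out) and lower numbers for less inhibition), compound 1 `Cn1cnc2c(Sc3ccccc3)ncnc21` gives 6% and compound 2 `Clc1ncnc2c1ncn2Cc1ccccc1` gives 3%. Compound 2 has the lower of the two numbers, yet its gap to compound 1 lies within the scatter, so the two look alike. Compound 3 `c1ccc(Cn2cnc3c(Sc4ccccc4)ncnc32)cc1` is not yet measured; it differs from compound 2 in one place: phenylsulfanyl in place of chloro on an aromatic carbon. For the measured compounds named here, no single-change step between measured compounds is known, and compound 1, which already carries phenylsulfanyl, gives 6%. A small step is expected, a number 2 percentage points higher from compound 2 to compound 3 (within the scatter), nothing beyond the scatter. Compound 3 is estimated at 5%, between 0% and 15%.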

Compound 3, a percentage reported as inhibition, at one concentration (the size of the read-out at that concentration, not a potency): 1%
Compound 3: middle estimate off by 4 percentage points, on the high side; the measured number falls inside the stated range.
By their numbers in this assay, from the lowest: compounds 3, 2 and 1 (each within the scatter of the next).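

In this assay, phenylsulfanyl in place of chloro on this aromatic carbon gives a number 2 percentage points lower from compound 2 to compound 3 (within the scatter), so a larger group carrying its own ring leaves the read-out effectively unchanged here. With phenylsulfanyl in place, phenyl in place of hydrogen on the saturated chain carbon bound to an aromatic nitrogen gives a number 5 percentage points lower from compound 1 to compound 3 (within the scatter), so that change also shows no clear effect. Nothing measured here accounts for either result. As far as these compounds go, whether an amine on this aromatic carbon, or a longer chain on the aromatic nitrogen, would raise the inhibition remains open.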